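The compounds below may be only part of what the source reports. "The series", "measured", "known", "first", "only" and "open" are said of these compounds alone.

Measured compounds:
- compound 1, `N#Cc1ccc(-c2nc(C(c3ccc(F)cc3)c3ccc(F)cc3)sc2CC(=O)O)cc1`, 150 nM
- compound 2, `N#Cc1cc(-c2nc(C(c3ccc(F)cc3)c3ccc(F)cc3)sc2CC(=O)O)ccc1F`, 57 nM
- compound 3, `Nc1cc(-c2nc(C(c3ccc(F)cc3)c3ccc(F)cc3)sc2CC(=O)O)cc(F)n1`, 220 nM

All three share a core and differ only in the aromatic ring attached to it, and all were tested in an in vitro assay on HEK385-7 cells for displacement of a labelled ligand from prostaglandin D2 receptor 2 (Homo sapiens); a lower number here means a stronger inhibitor, a higher number a weaker inhibitor. Compound 3 stands at the high end of the three values: the gap from compound 1 is a 1.5-fold higher number from compound 1 to compound 3 (0.17 log units; within the scatter), within the scatter, while the gap from compound 2 is a 3.9-fold higher number from compound 2 to compound 3 (0.59 log units; beyond the scatter), beyond it.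

Compound 4, `CN(C)c1cc(-c2nc(C(c3ccc(F)cc3)c3ccc(F)cc3)sc2CC(=O)O)ccn1`, has not yet been measured. Its change from compound 3 is 2-(dimethylamino)pyridin-4-yl in place of 2-amino-6-fluoropyridin-4-yl on an aromatic carbon. Among the compounds with values here, no measured step swaps between two pyridine rings of this kind, so nothing bears on it directly; the two steps that do touch the leaving ring show that swapping this ring moves the number by modest amounts at most. The step from compound 3 to compound 4 is therefore expected to be small, around a 1.1-fold lower number from compound 3 to compound 4 (0.04 log units; within the scatter), with no clear direction. Compound 4 is estimated at 200 nM, within a range from 60 nM to 700 nM.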

Compound 4, half-maximal inhibitory concentration: 380 nM
Compound 4: middle estimate off by 1.9-fold (0.28 log units), on the low side; the measured number falls inside the stated range.
By their numbers in this assay, from the lowest: compound 2; then compounds 1, 3 and 4 (each within the scatter of the next, the first and the last beyond it).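

In this assay, within the data shown here, this is the first comparison of two pyridine rings at this position: the step is a 1.7-fold higher number from compound 3 to compound 4 (0.24 log units; within the scatter), so replacing 2-amino-6-fluoropyridin-4-yl with 2-(dimethylamino)pyridin-4-yl does not clearly separate the two compounds. The wider gaps are to the nitrile-bearing phenyl rings, a 2.5-fold higher number from compound 1 to compound 4 (0.40 log units; beyond the scatter) and a 6.7-fold higher number from compound 2 to compound 4 (0.82 log units; beyond the scatter), so both of those rings give lower numbers than the 2-(dimethylamino)pyridin-4-yl ring, although compound 3 goes against any simple split between phenyl and pyridine rings by staying within the scatter of compound 1. No available evidence explains these differences.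

From the compounds shown here alone, the step from compound 3 to compound 4 changes the amino group and removes the fluorine together, so the contribution of each remains open. A 2-aminopyridin-4-yl ring, carrying the amine without the fluorine, would help separate the two changes.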